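Acetylated morpholine replaces the lactam ring

The source may hold more compounds than are shown below. What is called first, only, known or untested is meant among the compounds shown, and "the series" means these compounds.

Measured compounds and their values:
compound 1 `CN1CCC(NC(=O)c2ccncc2Nc2cc(-c3ccc4ccn(C)c4c3)c3nccnc3c2)CC1` gives 19500 nM
compound 2 `CC(=O)N1CCCC(NC(=O)c2ccncc2Nc2cc(-c3ccc4ccn(C)c4c3)c3nccnc3c2)C1` gives 13500 nM
compound 3 `CN1CC(NC(=O)c2ccncc2Nc2cc(-c3ccc4ccn(C)c4c3)c3nccnc3c2)CCC1=O` gives 96500 nM

All three share the same core and differ only in the saturated ring attached to the amide nitrogen. In an assay on lysate for inhibition of 6-phosphofructo-2-kinase/fructose-2,6-bisphosphatase 3 (Homo sapiens), with stated times of 0.5 min and 45 min (a higher number here means a weaker inhibitor, a lower number a stronger inhibitor), compound 3 holds the highest number of the three, which means it is the weakest inhibitor; the step of a 4.9-fold higher number from compound 1 to compound 3 (0.69 log units; beyond the scatter) and the step of a 7.1-fold higher number from compound 2 to compound 3 (0.85 log units; beyond the scatter) both lie beyond the scatter, while a 1.4-fold lower number from compound 1 to compound 2 (0.16 log units; within the scatter) does not.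

Compound 4 `CC(=O)N1CCOC(CNC(=O)c2ccncc2Nc2cc(-c3ccc4ccn(C)c4c3)c3nccnc3c2)C1` is the unmeasured one. Its change from compound 3 is (4-acetylmorpholin-2-yl)methyl in place of 1-methyl-6-oxopiperidin-3-yl on an amide-type nitrogen. The entering group carries an acetyl on a ring nitrogen, as the group in compound 2 does, and the measured step from compound 2 to compound 3 showed that moving from that acetylated ring to the lactam ring cost a modest amount. Reversing such a change is therefore expected to lower the number again, roughly back toward the range of compounds 1 and 2, though the added methylene link and the second ring oxygen have no measured precedent here. The expected step is a 3.9-fold lower number from compound 3 to compound 4 (0.59 log units; beyond the scatter). For compound 4 in this assay the estimate is 25000 nM, with a range from 8000 nM to 80000 nM.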

Compound 4, half-maximal inhibitory concentration: > 100000 nM
Compound 4 gave a limit, no number (the forecaster's own chance of this, stated with the estimate: 10%); middle value at least 4.0-fold (0.60 log units) away from the limit.
By their numbers in this assay, from the lowest: compounds 2 and 1 (each within the scatter of the next); then compound 3. At a limit, above all of these: compound 4.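

In this assay compound 4 gives a limit and not a number: the limit of > 100000 nM in this assay, at which 1 of the 4 values shown sits. An acetyl on a ring nitrogen therefore does not by itself keep a compound in the range of the two lowest numbers: (4-acetylmorpholin-2-yl)methyl in place of 1-acetylpiperidin-3-yl gives an at least 7.4-fold higher number from compound 2 to compound 4 (0.86 log units; beyond the scatter), and in place of 1-methylpiperidin-4-yl it gives an at least 5.1-fold higher number from compound 1 to compound 4 (0.70 log units; beyond the scatter). Against 1-methyl-6-oxopiperidin-3-yl the result reads an at least 1.0-fold higher number from compound 3 to compound 4 (0.01 log units; that floor lies within the scatter), and this floor does not put those two compounds in order, so the groups on this amide-type nitrogen that sit at the weak end now include both a lactam ring and an acetylated morpholine ring.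

The change brings in a methylene link and a second ring oxygen together, and the compounds shown do not separate what each of them contributes. Also open, going by these compounds, is how a free amine or a carboxylic acid in place of the acetyl on the morpholine ring would read in this assay.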